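Pyridin-4-yl in place of 3-fluorophenyl in compound 2

This account rests on a few compounds, and the source may have more. Where it says the series, first, only, none or still open, it means among the compounds named here.

In a functional assay on MCF7 cells (Homo sapiens) for antiproliferative activity, read by MTT assay, with a stated time of 48 h (on this read-out lower numbers stand for stronger inhibition and higher numbers for weaker inhibition), compound 2 (`CC(=O)N1N=C(c2ccc3ccccc3c2)OC1c1cccc(F)c1`) gives 1.98 ug/mL and lies within the scatter of both other measured compounds, compound 1 (`CC(=O)N1N=C(c2ccc3ccccc3c2)OC1c1ccccc1F`) at 3.44 ug/mL and compound 3 (`CC(=O)N1N=C(c2ccc3ccccc3c2)OC1c1ccc2ccccc2c1`) at 1.01 ug/mL on the same read-out. Compound 4 (`CC(=O)N1N=C(c2ccc3ccccc3c2)OC1c1ccncc1`) differs from compound 2 on the saturated ring carbon, with pyridin-4-yl in place of 3-fluorophenyl on a saturated ring carbon as the change. Among the compounds with values here, only one measured step bears on this carbon, a 1.7-fold lower number from compound 1 to compound 2 (0.24 log units; within the scatter) and thus within the scatter, and no measured compound has a ring hetero atom there. The expected step in this assay is a 1.1-fold higher number from compound 2 to compound 4 (0.05 log units; within the scatter) and so stays within the scatter, with no clear direction expected. Compound 4 is estimated at 2.2 ug/mL (range 0.8 ug/mL to 6 ug/mL) in this measurement.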

Compound 4, half-maximal inhibitory concentration: 2.56 ug/mL
Beside the measured number, compound 4's estimate is 1.2-fold (0.07 log units) below it, within the range that was stated.
By their numbers in this assay, from the lowest: compounds 3, 2, 4 and 1 (each within the scatter of the next, the first and the last beyond it).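

In this assay, putting pyridin-4-yl on the saturated ring carbon gives a 1.3-fold higher number from compound 2 to compound 4 (0.11 log units; within the scatter) and a 1.3-fold lower number from compound 1 to compound 4 (0.13 log units; within the scatter). Within the data shown here, the earlier compounds carried only carbon aromatic rings there, so this is the first sign that a ring nitrogen, with its hydrogen-bond acceptor, separates compound 4 from neither fluorophenyl compound. No independent evidence bears on this result. The compounds shown leave open whether an amine or a carboxylic acid on this carbon would move the number beyond the scatter.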